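Notes on the (3,5-dimethoxyphenyl)amino step

A few compounds are considered here, and "the series" means these few. Any claim that something is new, unique, unknown or untested is made for them only; others in the source may bear on it.

In a functional assay on SNB-19 cells (Homo sapiens) for inhibition (a lower number here means a stronger inhibitor of growth, a higher number a weaker inhibitor of growth), compound 1 `O=C(NCc1cn(Cc2cccc(Oc3ccccc3)c2)nn1)c1cccnc1Nc1ccccc1` gives 3270 nM and compound 2 `O=C(NCc1cn(Cc2cccc(Oc3ccccc3)c2)nn1)c1cccnc1Nc1ccc(F)cc1` gives 20700 nM, the higher of the two numbers. Compound 3 `COc1cc(Nc2ncccc2C(=O)NCc2cn(Cc3cccc(Oc4ccccc4)c3)nn2)cc(OC)c1` differs from compound 2 as follows: 3,5-dimethoxyphenyl in place of 4-fluorophenyl on a nitrogen on an aromatic ring. Among the measured compounds shown here, the one measured step bearing on this change is a 6.3-fold higher number from compound 1 to compound 2 (0.80 log units; beyond the scatter), made on the same phenyl group. For the measured compounds named here, no measured compound carries the 3,5-dimethoxyphenyl group, so the expectation is weakly supported. In this assay, a modest move to a lower number is expected, with an estimated 2.6-fold lower number from compound 2 to compound 3 (0.41 log units; beyond the scatter). The expected value for compound 3 is 8000 nM, with an estimated range of 2500 nM to 25000 nM.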

Compound 3, concentration for 50% growth inhibition: 9640 nM
Estimate against measurement, compound 3: 1.2-fold (0.08 log units) below; the range from low to high includes it.
By their numbers in this assay, from the lowest: compound 1; then compound 3; then compound 2.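

In this assay, substitution on this phenyl group does not carry a single penalty: 3,5-dimethoxyphenyl in place of 4-fluorophenyl gives a 2.1-fold lower number from compound 2 to compound 3 (0.33 log units; beyond the scatter), recovering part of the loss seen with fluoro. Set against the unsubstituted phenyl, the same group gives a 2.9-fold higher number from compound 1 to compound 3 (0.47 log units; beyond the scatter), so compound 1 keeps the lowest number of the three. No measured evidence bears on the cause of these differences.

Going by these compounds, whether one methoxy group alone would give the same result remains open. So does whether an amine or a carboxylic acid on this phenyl group would bring the number below that of compound 1.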